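A few compounds are considered here, and "the series" means these few. Any claim that something is new, unique, unknown or untested is made for them only; others in the source may bear on it.

Compound 1 `COC(=O)COc1ccc(/C=C/C(=O)CC(=O)/C=C/c2ccc(OC)c(OC)c2)cc1OC` gives 25.2% in a functional assay on the whole organism (Ear, strain ICR) for inhibition, with Mus musculus as the target, with stated times of 30 min and 2 h, at a dose of 1 umol/kg by the oral route; on this read-out lower numbers stand for less inhibition and higher numbers for more inhibition at the one dose given (going by the name of the read-out). Compound 2 `COc1cc(/C=C/C(=O)CC(=O)/C=C/c2ccc(OCC(=O)N[C@@H](CCCCNC(=O)[C@H](CCCCN)NC(=O)[C@H](C)NC(=O)[C@H]3CCNC3)C(=O)O)c(OC)c2)ccc1O` gives 62% in this assay, the highest of the two numbers, and compound 1 lies lower by an amount beyond the scatter. Compound 3 `COc1ccc(/C=C/C(=O)CC(=O)/C=C/c2ccc(OCC(=O)N[C@@H](CCCCNC(=O)[C@H](CCCCN)NC(=O)[C@H](C)NC(=O)[C@H]3CCNC3)C(=O)O)c(OC)c2)cc1OC` is not yet measured; relative to compound 2 the change is methyl in place of hydrogen on an oxygen on an aromatic ring. Among the compounds with values here, no pair differing in one place has been measured, so there is no direct guide for this step. A small drop is expected, though none beyond the scatter would also fit. For compound 3 the estimate in this assay is 50%, within 30% to 70%, an expected step of a number 12 percentage points lower from compound 2 to compound 3 (beyond the scatter).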

Compound 3, a percentage reported as inhibition, in the whole organism at one dose (the size of the read-out at that dose, not a potency): 57.7%
Estimate against measurement, compound 3: 7.7 percentage points below, within the range that was stated.
By their numbers in this assay, from the lowest: compound 1; then compounds 3 and 2 (each within the scatter of the next).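

In this assay, within the data shown here, the first one-place comparison gives a number 4.3 percentage points lower from compound 2 to compound 3 (within the scatter) for hydroxy to methoxy, the change from 4-hydroxy-3-methoxyphenyl to 3,4-dimethoxyphenyl. At this one dose, the assay therefore does not separate the free hydroxy from its methyl ether at this position. No measurement available here accounts for this result. Still open, as far as these compounds go, is how a longer chain such as ethyl or benzyl on this oxygen would read, or an amine in place of the hydroxy. The same holds for a carboxylic acid at this position.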